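The compounds below may be only part of what the source reports. "The series", "measured", "known", "first", "only" and "open" are said of these compounds alone.

Working notes on the series. The shared core carries a urea-linked aryl group, and the assay throughout is a functional assay on RT-112 cells (Homo sapiens) for antiproliferative activity, read by MTT assay, with a stated time of 72 h; a higher number here means a weaker inhibitor of growth, a lower number a stronger inhibitor of growth. Compound 1 `COc1cc(Nc2ncnc3c(NC(=O)Nc4ccc(C)c(C)c4)cccc23)cc(OC)c1` gives 8.8 nM in this assay, the lowest of the two numbers recorded. Compound 3 `COc1cc(Nc2ncnc3c(NC(=O)Nc4cc(C)cc(C)c4)cccc23)cc(OC)c1` gives 10100 nM in this assay. The step of a 1100-fold higher number from compound 1 to compound 3 (3.06 log units; beyond the scatter) shows that moving one methyl on that ring from the 3,4-arrangement to the 3,5-arrangement is enough to remove nearly all of the activity. Compound 2 `COc1cc(Nc2ncnc3c(NC(=O)Nc4ccc(C(F)(F)F)cc4[N+](=O)[O-])cccc23)cc(OC)c1` reaches only a limit in this assay, > 20000 nM, which is the limit of > 20000 nM in this assay, at which 1 of the 3 values shown sits.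

Compound 4 `COc1cc(Nc2ncnc3c(NC(=O)Nc4ccc(C(F)(F)F)cc4)cccc23)cc(OC)c1` is not yet measured. It differs from compound 1 by 4-(trifluoromethyl)phenyl in place of 3,4-dimethylphenyl on an amide-type nitrogen. Within the data shown here, no measured step addresses this exact change. Among the measured compounds shown here, the only step in hand, from compound 1 to compound 3, concerns the dimethyl pattern and not a trifluoromethyl group, and compound 2 carries the trifluoromethyl together with a nitro group, so its limit cannot be separated into either contribution. The substitution in compound 4 keeps the 4-position occupied, as in compound 1, but a loss of some size is expected.

Compound 4 is therefore estimated at 120 nM in this assay, within 10 nM to 3000 nM, an expected step of a 14-fold higher number from compound 1 to compound 4 (1.13 log units; beyond the scatter).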

Compound 4, concentration for 50% growth inhibition: 3920 nM
For compound 4 the middle estimate is 33-fold (1.51 log units) below the measured one; the whole stated range lies below it.
By their numbers in this assay, from the lowest: compound 1; then compound 4; then compound 3. At a limit, above all of these: compound 2.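

In this assay, 4-(trifluoromethyl)phenyl on the amide-type nitrogen gives a 450-fold higher number from compound 1 to compound 4 (2.65 log units; beyond the scatter), a second large loss at this place, now from a group other than 3,5-dimethylphenyl, and compound 1 remains the only compound shown with a low number. Measured against 3,5-dimethylphenyl, the same group gives a 2.6-fold lower number from compound 3 to compound 4 (0.41 log units; beyond the scatter), a modest gap that is beyond the scatter, so the two replacements of 3,4-dimethylphenyl can still be told apart in this assay. Hydrogen in place of nitro gives an at least 5.1-fold lower number from compound 2 to compound 4 (0.70 log units; beyond the scatter), a step read from a limit and not from a number, which shows that the trifluoromethyl-bearing ring gives a measurable value once the nitro group is gone: the limit of > 20000 nM in this assay, at which 1 of the 4 values shown sits.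

The compounds shown leave open whether the step to compound 4 follows from the trifluoromethyl group itself or from the loss of the 3,4-dimethylphenyl pattern. They also leave open how a methoxy group, a chlorine atom or an amine on this aryl ring would read at this place.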